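The source may report more compounds than this note shows. Statements on the series, on what has been measured and on what is new or still open speak of the compounds shown alone.

Working notes on the series. In a physicochemical assay for lipophilicity, read by HPLC, measured as chromatographic lipophilicity, at pH 7.4 (a lower number here means a more polar compound, a higher number a more lipophilic compound), compound 1 `COc1cccc(NC(=O)c2nnn(CC3CCNCC3)c2N)c1` gives 0.6. Compound 2 `COc1cccc(NC(=O)c2nnn(Cc3ccc(-n4cccn4)cc3)c2N)c1` gives 2.4 in this assay, and compound 3 `COc1cccc(NC(=O)c2nnn(Cc3ccccc3)c2N)c1` gives 2.6. Compound 3 thus carries the highest of the three numbers, though the gap to compound 2 is within the scatter and no order between those two is claimed; the step of a number 2.00 log units higher from compound 1 to compound 3 (beyond the scatter) is the one large movement in the set.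

Compound 4 `COc1cccc(NC(=O)c2nnn(Cc3ccc(OC(F)(F)F)cc3)c2N)c1` has not yet been measured in this assay. It differs from compound 3 by trifluoromethoxy in place of hydrogen on an aromatic carbon. Of the measured steps, a number 0.20 log units higher from compound 2 to compound 3 (within the scatter) is the nearer comparison, an exchange of a substituent for hydrogen on an aromatic carbon of the same ring, and it stayed within the scatter. The step of a number 2.00 log units higher from compound 1 to compound 3 (beyond the scatter) concerns the group on the saturated chain carbon and bears only loosely on the present change. The measured comparisons therefore give no direction beyond the scatter on their own. For compound 4 a step upward is nonetheless expected, a number 0.80 log units higher from compound 3 to compound 4 (beyond the scatter). The estimate for compound 4 in this assay is 3.4, expected to fall between 2.8 and 4.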

Compound 4, distribution coefficient: 3.6
Compound 4: middle estimate off by 0.20 log units, on the low side; the measured number falls inside the stated range.
By their numbers in this assay, from the lowest: compound 1; then compounds 2 and 3 (each within the scatter of the next); then compound 4.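

In this assay, the aromatic carbon para to a large group now shows a movement beyond the scatter, a number 1.00 log units higher from compound 3 to compound 4 (beyond the scatter) on trifluoromethoxy in place of hydrogen, whereas the exchange of 1H-pyrazol-1-yl for hydrogen on that carbon had stayed within the scatter. The position is therefore not indifferent to what it carries: the two substituents themselves stand apart, a number 1.20 log units higher from compound 2 to compound 4 (beyond the scatter) for trifluoromethoxy in place of 1H-pyrazol-1-yl, a large step between groups whose exchanges for hydrogen differ so clearly in size. No measurement shown bears on why trifluoromethoxy moves the number while 1H-pyrazol-1-yl does not.

The compounds shown rest on only two substituents at this carbon, so it stays open how a smaller or differently built group there, such as a single fluorine, a nitrile, an amine or a carboxylic acid, would fall relative to hydrogen and trifluoromethoxy. Also open, on these data alone, is whether the step on trifluoromethoxy would keep its size with the group on another carbon of the ring, or on a compound with a different group on the saturated chain carbon.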